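The source may report more compounds than this note shows. Statements on the series, on what has been measured and on what is new or still open speak of the compounds shown alone.

Compound 1 `CN1CCN(c2ccc(Nc3ncc4nc(Nc5ccc(F)cc5)n([C@H]5CCCN(S(=O)(=O)C6CC6)C5)c4n3)cc2)CC1`: 1150 nM
Compound 2 `CN1CCN(c2ccc(Nc3ncc4nc(Nc5ccc(F)cc5)n([C@H]5CCCC(NC(=O)OC(C)(C)C)C5)c4n3)cc2)CC1`: "not determined" (no result reported)
Compound 3 `CN1CCN(c2ccc(Nc3ncc4nc(Nc5ccccc5)n([C@H]5CCN(S(C)(=O)=O)C5)c4n3)cc2)CC1`: "not determined" (no result reported)

In a functional assay on NCI-H1975 cells (Homo sapiens) for antiproliferative activity, read by MTT assay, with a stated time of 72 h (a higher number here means a weaker inhibitor, a lower number a stronger inhibitor), compound 3 has no number to stand on, and compound 2 is in the same position, so only compound 1 gives a reference point. Compound 4 `CN1CCN(c2ccc(Nc3ncc4nc(Nc5ccccc5)n([C@H]5CCN(S(=O)(=O)C6CC6)C5)c4n3)cc2)CC1` follows from compound 3 through one change, cyclopropyl in place of methyl on a sulfonyl sulfur. Among the compounds with values here, no measured pair shows this change, so the step can only be expected, and no step beyond the usual scatter is expected in this assay, in either direction. The closest guide is compound 1, which also carries cyclopropylsulfonyl and gives 1150 nM, though it differs elsewhere. For compound 4 the estimated value is 1000 nM, with an expected range of 300 nM to 3500 nM.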

Compound 4, half-maximal inhibitory concentration: 240 nM
The estimate for compound 4 lay 4.2-fold (0.62 log units) above the measured number; measured number outside the range, below it.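

Within the data shown here, compound 3 has no single number in this assay, so no step to compound 4 can be read. Whether methylsulfonyl to cyclopropylsulfonyl shifts activity stays open, and no evidence shown bears on this result.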